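Trifluoromethyl added to compound 2: expected step

The compounds below may be only part of what the source reports. "The series", "measured", "known", "first", "only" and "open" are said of these compounds alone.

In a functional assay on the whole organism for inhibition, with Homo sapiens as the target (on this read-out higher numbers stand for weaker inhibition and lower numbers for stronger inhibition), compound 2 `CCN(C[Si](C)(C)c1ccccc1)c1ccccc1` gives 15000 nM as the second highest of three numbers. Compound 1 `C[Si](C)(CNc1ccccc1)c1ccccc1` stands at 7800 nM within the scatter of it, and compound 3 `CCN(C[Si](C)(C)c1ccccc1)c1ccc(C(F)(F)F)cc1` stands at 100000 nM beyond the scatter. Compound 4 `CCN(C[Si](C)(C)c1ccc(C(F)(F)F)cc1)c1ccccc1` is not yet measured and differs from compound 2 by trifluoromethyl in place of hydrogen on an aromatic carbon as trifluoromethyl in place of hydrogen on an aromatic carbon, para to a large group. The nearest guide is the step of a 6.7-fold higher number from compound 2 to compound 3 (0.82 log units; beyond the scatter) for the same replacement at another aromatic carbon. The step of a 1.9-fold higher number from compound 1 to compound 2 (0.28 log units; within the scatter) concerns the nitrogen and gives no guide. The expected step of a 2.7-fold higher number from compound 2 to compound 4 (0.43 log units; beyond the scatter) in this assay is estimated to run the same way, at similar or smaller size. For compound 4 the estimated value is 40000 nM with an expected range from 12000 nM to 120000 nM in this assay.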

Compound 4, half-maximal inhibitory concentration: 20000 nM
Beside the measured number, compound 4's estimate is 2.0-fold (0.30 log units) above it; the measured number falls inside the stated range.
By their numbers in this assay, from the lowest: compounds 1, 2 and 4 (each within the scatter of the next, the first and the last beyond it); then compound 3.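

In this assay, trifluoromethyl in place of hydrogen on this aromatic carbon, para to a large group, gives a 1.3-fold higher number from compound 2 to compound 4 (0.12 log units; within the scatter) and is therefore tolerated here. The same replacement at another aromatic carbon gives a 6.7-fold higher number from compound 2 to compound 3 (0.82 log units; beyond the scatter) and so, in these compounds, the outcome differs with the carbon that carries the group. No evidence is available on the reason for this difference.

As far as these compounds go, whether a methoxy group, a nitrile or a carboxylic acid at this carbon would stay within the scatter of compound 2 remains open. Also open, from the compounds shown here alone, is whether trifluoromethyl at this carbon would behave the same way on compound 1, which carries hydrogen in place of the ethyl on the nitrogen.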